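Piperazine dithiocarbamate benzamides: aryl to arylmethyl on the ring nitrogen

The source may report more compounds than this note shows. Statements on the series, on what has been measured and on what is new or still open speak of the compounds shown alone.

Three members of the series have numbers in a functional assay on A-375 cells (Homo sapiens) for antiproliferative activity, read by CCK-8 assay, with a stated time of 72 h, tested at 8 uM (on this read-out higher numbers stand for a stronger effect at the one concentration tested and lower numbers for a weaker effect), so far. Compound 1 `Nc1ccccc1NC(=O)c1ccc(CSC(=S)N2CCN(C(c3ccccc3)c3ccccc3)CC2)cc1` gives 8.4% in this assay. Compound 2 `Nc1ccccc1NC(=O)c1ccc(CSC(=S)N2CCN(c3cccnc3)CC2)cc1` gives 88.8% in this assay, and compound 3 `Nc1ccccc1NC(=O)c1ccc(CSC(=S)N2CCc3cc(Cl)ccc32)cc1` gives 82.3% in this assay. Compound 2 and compound 3 therefore lie within the usual scatter of each other, while both stand far above compound 1, whose number is beyond the scatter from either.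

Compound 4 `Nc1ccccc1NC(=O)c1ccc(CSC(=S)N2CCN(Cc3ccncc3)CC2)cc1` has not yet been measured in this assay. It differs from compound 2 in one place: (pyridin-4-yl)methyl in place of pyridin-3-yl on an amine nitrogen in a ring. Among the compounds with values here, no step between two measured compounds covers this kind of change, so the expectation rests on the spread of the three numbers only. Since the large substituent of compound 1 that sits on the same ring nitrogen goes with 8.4%, a step downward from compound 2 of modest size, a number 18.8 percentage points lower from compound 2 to compound 4 (beyond the scatter), is expected for compound 4, with a wide range. Compound 4 is estimated at 70%, between 35% and 92%.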

Compound 4, a percentage reported as inhibition, at one concentration (the size of the read-out at that concentration, not a potency): 89.5%
The estimate for compound 4 lay 19.5 percentage points below the measured number; measured number inside the range.
By their numbers in this assay, from the lowest: compound 1; then compounds 3, 2 and 4 (each within the scatter of the next).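

In this assay, (pyridin-4-yl)methyl in place of pyridin-3-yl on the ring nitrogen gives a number 0.7 percentage points higher from compound 2 to compound 4 (within the scatter), so the two groups cannot be told apart on this read-out. An arylmethyl group on this nitrogen can therefore go with a high number, and the low number of compound 1 at 8.4% is not a feature of every group joined there through a carbon. No measurement at hand accounts for this result.

The step changes the attachment and the place of the pyridine nitrogen together, so the compounds shown do not separate these two changes. Also open, from the compounds shown here alone, is how far this position tolerates other groups, such as a plain benzyl, a longer chain ending in pyridine, or a carboxylic acid, and a single-concentration read-out leaves the potencies of compound 2 and compound 4 unresolved.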